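The source may report more compounds than this note shows. Statements on the series, on what has been measured and on what is new or still open speak of the compounds shown alone.

In a functional assay on MDA-MB-231 cells (Homo sapiens) for antiproliferative activity, read by MTT assay, with a stated time of 72 h (a higher number here means a weaker inhibitor, a lower number a stronger inhibitor), compound 1 `O=C(CCc1cccc2c1B(O)OC2)Nc1ccccc1`, with a plain phenyl on the amide-type nitrogen, gives 230 nM. Compound 2 `O=C(CCc1cccc2c1B(O)OC2)NCc1ccccc1`, with benzyl there, reaches only a limit of the assay, > 100000 nM. Compound 3 `O=C(CCc1cccc2c1B(O)OC2)Nc1ccc(I)cc1` gives 33000 nM, the higher of the two values that are true numbers.

Compound 4 `O=C(CCc1cccc2c1B(O)OC2)Nc1cccc(Br)c1` has not yet been measured. Its change from compound 3 is 3-bromophenyl in place of 4-iodophenyl on an amide-type nitrogen.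

The most relevant measured step is a 140-fold higher number from compound 1 to compound 3 (2.16 log units; beyond the scatter), a large rise that came with iodo in place of hydrogen on an aromatic carbon. The step of an at least 3.0-fold lower number from compound 2 to compound 3 (0.48 log units; beyond the scatter) is smaller and shows that compound 3 still keeps a measurable number. Among the measured compounds shown here, no bromo compound has been measured, so compound 1 and compound 3 serve as the only guides, and compound 4 is expected to fall between them.

The expected change is an 11-fold lower number from compound 3 to compound 4 (1.04 log units; beyond the scatter), a clear move toward a lower number. For compound 4 the estimate is 3000 nM, with an expected range from 400 nM to 25000 nM.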

Compound 4, half-maximal inhibitory concentration: 720 nM
Compound 4: the middle estimate sits 4.2-fold (0.62 log units) above what was measured; the range from low to high includes it.
By their numbers in this assay, from the lowest: compound 1; then compound 4; then compound 3. At a limit, above all of these: compound 2.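

Compound 4 shows that a halogen on the phenyl ring need not cost much in this series, with a 3.1-fold higher number from compound 1 to compound 4 (0.50 log units; beyond the scatter), so the large rise seen with compound 3 is not shared by every halogen-bearing phenyl. Exchanging 4-iodophenyl for 3-bromophenyl recovers most of that loss, with a 46-fold lower number from compound 3 to compound 4 (1.66 log units; beyond the scatter), and compound 4 also stands far from the benzyl amide, with an at least 130-fold lower number from compound 2 to compound 4 (2.14 log units; beyond the scatter). Compound 2 stands at a limit of the assay: the limit of > 100000 nM in this assay, at which 1 of the 4 values shown sits.

The identity of the halogen and its place on the ring change together between compound 3 and compound 4, so their separate contributions cannot be told apart. On these data alone, it also remains open whether a phenyl ring carrying an amine or a carboxylic acid instead of a halogen would stay close to compound 1.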